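Nitro to chloro on the pendant phenyl of compound 1

The source may report more compounds than this note shows. Statements on the series, on what has been measured and on what is new or still open speak of the compounds shown alone.

Compound 1 `O=C1C(O)=C(C(c2ccc([N+](=O)[O-])cc2)c2c[nH]c3ccccc23)C(=O)c2ccccc21` is the weakest of the compounds in hand: in a toxicity assay (Homo sapiens) for cytotoxicity, read by MTT assay, with a stated time of 48 h (a higher number here means a weaker inhibitor, a lower number a stronger inhibitor), compound 1 gives only the limit > 200000 nM, so its true number sits beyond the top of the scale (the limit of > 200000 nM in this assay, at which 1 of the 3 values shown sits). Compound 2 `COc1cccc(C(C2=C(O)C(=O)c3ccccc3C2=O)c2c[nH]c3ccccc23)c1` gives 110000 nM, and compound 3 `O=C1C(O)=C(C(c2ccccc2)c2c(-c3ccccc3)[nH]c3ccccc23)C(=O)c2ccccc21`, which differs in two places, gives 26400 nM. Compound 4 `O=C1C(O)=C(C(c2ccc(Cl)cc2)c2c[nH]c3ccccc23)C(=O)c2ccccc21` carries the change (chloro in place of nitro on an aromatic carbon). For the measured compounds named here, the only measured step touching the same carbon is an at least 1.8-fold lower number from compound 1 to compound 2 (0.25 log units; that floor lies within the scatter), a drop whose size is uncertain because compound 1 is a limit. A similar or smaller downward move in this assay is therefore expected, with a fair chance of another limit. Compound 4 is estimated at 110000 nM (range 40000 nM to 250000 nM), a step of an at least 1.8-fold lower number from compound 1 to compound 4 (0.25 log units; that floor lies within the scatter).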

Compound 4, half-maximal inhibitory concentration: 102000 nM
Beside the measured number, compound 4's estimate is 1.1-fold (0.03 log units) above it; measured number inside the range.
By their numbers in this assay, from the lowest: compound 3; then compounds 4 and 2 (each within the scatter of the next). At a limit, above all of these: compound 1.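

Placing 4-chlorophenyl at this position gives a measured number in this assay where 4-nitrophenyl gave only a limit, and the change reads as an at least 1.9-fold lower number from compound 1 to compound 4 (0.29 log units; that floor lies within the scatter) at this stage. From the compounds shown here alone, the value of compound 1 is a limit and not a number, so the full size of that step stays unknown: the limit of > 200000 nM in this assay, at which 1 of the 4 values shown sits. The comparison with the 3-methoxyphenyl compound reads as a 1.1-fold lower number from compound 2 to compound 4 (0.03 log units; within the scatter) and so separates neither group from the other.

Going by these compounds, whether an amine or a carboxylic acid on this phenyl ring would move the number beyond the scatter stays open.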